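Thiophen-2-yl in place of 2,6-difluorophenyl: working notes

This account rests on a few compounds, and the source may have more. Where it says the series, first, only, none or still open, it means among the compounds named here.

The series starts from compound 1 `OC[C@H]1N/C(=N/O)[C@H](O)[C@@H](O)[C@@H]1O`. In an assay on isolated protein for inhibition of alpha-galactosidase (Coffea arabica) (a higher number here means a weaker inhibitor, a lower number a stronger inhibitor), compound 1 reaches only a limit of the assay, > 100000 nM. Compound 2 `O=C(Nc1c(F)cccc1F)O/N=C1\N[C@H](CO)[C@@H](O)[C@H](O)[C@H]1O` builds on the same core. In this assay compound 2 likewise gives only a limit, > 100000 nM. Both values shown sit at the same limit (the limit of > 100000 nM in this assay, at which 2 of the 2 values shown sit), so compound 2 stands nowhere on a measured scale; the numbers show no difference between compound 1 and compound 2, only that neither is caught by the assay.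

Compound 3 `O=C(Nc1cccs1)O/N=C1\N[C@H](CO)[C@@H](O)[C@H](O)[C@H]1O` differs from compound 2 in one place: thiophen-2-yl in place of 2,6-difluorophenyl on an amide-type nitrogen. Going by the values given here, no step between measured compounds exists in this assay, and the only guide is the shared limit (the limit of > 100000 nM in this assay, at which 2 of the 2 values shown sit). The expected step from compound 2 to compound 3 is a number no higher from compound 2 to compound 3 (the limit leaves the size open), that is, none beyond the scatter, with compound 3 expected to stay at the limit. Compound 3 is therefore estimated at 100000 nM, within a range of 30000 nM to 300000 nM.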

Compound 3, half-maximal inhibitory concentration: > 100000 nM
Compound 3: only a limit was reported; the forecaster's own chance of this, stated with the estimate: 80%; the middle value lies on the limit itself.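

In this assay compound 3 gives > 100000 nM, which is a limit of the assay. Compound 2 also gives only a limit, so no step can be read between compound 2 and compound 3: the limit of > 100000 nM in this assay, at which 3 of the 3 values shown sit.

The compounds shown leave open whether thiophen-2-yl and 2,6-difluorophenyl differ at all in this assay, and how strongly compound 1, compound 2 or compound 3 inhibits.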